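Compound 3 to compound 4: a carbamoyl group exchanged

The source may report more compounds than this note shows. Statements on the series, on what has been measured and on what is new or still open speak of the compounds shown alone.

Measured in a functional assay on A549 cells (Homo sapiens) for antiproliferative activity, read by sulforhodamine B assay, with a stated time of 3 days; on this read-out lower numbers stand for stronger inhibition of growth and higher numbers for weaker inhibition of growth:
compound 1 `COc1ccc(N2CCN(C)CC2)cc1Nc1ncc(F)c(Nc2ccc(F)cc2)n1`: 1130 nM
compound 2 `O=C(Nc1ccc(C(F)(F)F)cc1)c1cccc(Nc2ncc(F)c(Nc3ccc(F)cc3)n2)c1`: > 10000 nM (a limit of the assay)
compound 3 `COc1ccc(NC(=O)c2cccc(Nc3ncc(F)c(Nc4ccc(F)cc4)n3)c2)cc1`: 11000 nM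

Of the two actual numbers, compound 3 has the higher at 11000 nM, and compound 1 lies lower at 1130 nM in the same read-out, a gap that exceeds the usual scatter. Compound 4 `CN1CCC(C(=O)Nc2cccc(Nc3ncc(F)c(Nc4ccc(F)cc4)n3)c2)CC1` carries ((1-methylpiperidin-4-yl)carbonyl)amino in place of (4-methoxyphenyl)carbamoyl on an aromatic carbon, meta to a large group: ((1-methylpiperidin-4-yl)carbonyl)amino in place of (4-methoxyphenyl)carbamoyl on an aromatic carbon. Going by the values given here, the one measured step, a step that the limit leaves unreadable from compound 2 to compound 3, cannot be read for size and concerns a different change, so it offers no guide. Among the compounds with values here, the only lower number, compound 1 at 1130 nM, weakly supports a moderate fall in this assay. The estimated move is a 2.8-fold lower number from compound 3 to compound 4 (0.44 log units; beyond the scatter), towards a lower number. For compound 4 the expected value is 4000 nM, with 1000 nM to 15000 nM as the estimated range.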

Compound 4, concentration for 50% growth inhibition: 1330 nM
Compound 4: middle estimate off by 3.0-fold (0.48 log units), on the high side; the range from low to high includes it.
By their numbers in this assay, from the lowest: compounds 1 and 4 (each within the scatter of the next); then compound 3.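

In this assay, putting ((1-methylpiperidin-4-yl)carbonyl)amino in place of (4-methoxyphenyl)carbamoyl gives an 8.3-fold lower number from compound 3 to compound 4 (0.92 log units; beyond the scatter). Going by these compounds alone, compound 2 and compound 3 both carry a carbamoyl group at this aromatic carbon and the step between them cannot be read, so this is the first readable sign that the group here matters to the read-out. Nothing measured among these compounds accounts for the size of the step. The exchange alters the ring and the amide together, so their shares remain unseparated. As far as these compounds go, whether a morpholine or a cyclohexane in place of the 1-methylpiperidine would give a similar number stays open.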